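A few compounds are considered here, and "the series" means these few. Any claim that something is new, unique, unknown or untested is made for them only; others in the source may bear on it.

Working notes on the series. In a functional assay on SH-SY5Y cells (Homo sapiens) for cytotoxicity, read by MTT assay, with stated times of 1 h and 24 h (on this read-out higher numbers stand for an effect only at larger amounts of compound and lower numbers for an effect already at smaller amounts), compound 1 `O=C(CCN1CCCCC1)c1cc2ccc(O)cc2oc1=O` reads > 100000 nM, which is a limit and not a number. Compound 2 `CN(C)CCC(=O)c1cc2cc(Br)c(O)c(Br)c2oc1=O` reads > 100000 nM, which is likewise a limit and not a number. Among the measured compounds shown here, compound 2 therefore has no measured number of its own, and the one other value shown gives no number to compare it with. For the measured compounds named here, the position of the series so far is the limit of > 100000 nM in this assay, at which 2 of the 2 values shown sit.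

Compound 3 `O=C(CCN1CCCC1)c1cc2cc(Br)c(O)c(Br)c2oc1=O` carries pyrrolidin-1-yl in place of dimethylamino on a saturated chain carbon, two bonds along the chain from a carbonyl carbon. The shared core and the bromo groups of compound 2 stay as they are. Going by the values given here, no step between measured compounds is available to size this change in this assay. No step beyond the scatter is expected, and no direction is favoured. This expectation rests on compound 2 at > 100000 nM, a limit.

The expected step is a number no higher from compound 2 to compound 3 (the limit leaves the size open). The estimate for compound 3 is 100000 nM, with an expected range from 30000 nM to 150000 nM, and a reading that is again only a limit is the likeliest outcome.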

Compound 3, half-maximal effective concentration: 75100 nM
Compound 3: middle estimate off by 1.3-fold (0.12 log units), on the high side, within the range that was stated.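

In this assay, pyrrolidin-1-yl in place of dimethylamino on a saturated chain carbon, two bonds along the chain from a carbonyl carbon, gives an at least 1.3-fold lower number from compound 2 to compound 3 (0.12 log units; that floor lies within the scatter). Among the compounds shown here, this is the first reading that is a number and not a limit, so the change at this position can be followed on this read-out, although the floor of the step stays within the scatter and its true size remains open. Compound 3 alone has left the limit, and the rest of the series still stands there: the limit of > 100000 nM in this assay, at which 2 of the 3 values shown sit.

The compounds shown leave open whether the number goes with the ring of pyrrolidin-1-yl or with the added carbons alone, a question that diethylamino or morpholin-4-yl on the same chain, with the bromo groups kept, would help to separate. The part played by the bromo groups is also open, as compound 1 differs from compound 3 in more than one place and no pair shown isolates them.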